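Halogen swap on the aryl ring of compound 1

This account rests on a few compounds, and the source may have more. Where it says the series, first, only, none or still open, it means among the compounds named here.

Measured so far in this series:
compound 1 `COC(=O)C1=C(C)N=C(C)/C(=C(\O)OC)C1c1cccc(Br)c1` — 1.29 nM
compound 2 `COC(=O)C1=C(C)N=C(C)/C(=C(/O)OC)C1c1c(F)cccc1Cl` — 7.59 nM

Two compounds of the shared core have been run in a functional assay (muscle tissue) with Cavia porcellus as the target; on this read-out lower numbers stand for an effect already at smaller amounts and higher numbers for an effect only at larger amounts of compound. Compound 1 gives 1.29 nM, the lower of the two numbers, and compound 2 gives 7.59 nM; the gap between them lies beyond the scatter. The two measured compounds do not differ in a single place, so no one-point step can be read from the data themselves.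

Compound 3 `COC(=O)C1=C(C)N=C(C)/C(=C(\O)OC)C1c1cccc(F)c1` is next to be measured. Against compound 1 it carries fluoro in place of bromo on an aromatic carbon. A halogen exchange of this kind is not covered by any measured pair here, so the size of the step rests on expectation alone. The working expectation is a moderate loss, with the step estimated at a 3.9-fold higher number from compound 1 to compound 3 (0.59 log units; beyond the scatter), beyond the usual scatter but not large. Compound 3 is accordingly expected to land at 5 nM, with a range from 1.5 nM to 20 nM.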

Compound 3, half-maximal effective concentration: 20.9 nM
Compound 3: the middle estimate sits 4.2-fold (0.62 log units) below what was measured; the whole stated range lies below it.
By their numbers in this assay, from the lowest: compound 1; then compound 2; then compound 3.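

In this assay, within the data shown here, the exchange of bromo for fluoro on an aromatic carbon, meta to a large group, gives the first one-point step, a 16-fold higher number from compound 1 to compound 3 (1.21 log units; beyond the scatter), and this step is large. This place on the aromatic ring is therefore not indifferent to which halogen it carries, even though the change replaces one heavy atom with another and leaves the counts of rings, hydrogen-bond donors, hydrogen-bond acceptors and net charge unchanged. No measurement at hand bears on what lies behind this step, so its size stands as an observation only.

The compounds shown leave open how chloro or iodo would read at this same place, and whether a non-halogen group such as methyl, methoxy, nitrile or trifluoromethyl would keep the low number of compound 1 or move away from it. Also open, going by these compounds, is whether the same exchange elsewhere on the aromatic ring would give a step of this size; compound 2 differs from compound 1 in more than one place and gives no reading on that.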